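The compounds below may be only part of what the source reports. "The series", "measured", "known", "first", "only" and "open" are said of these compounds alone.

Working notes on the series.

Compound 1 `COC[C@H](C)[C@H](C)C(c1ccc(O)c(OC)c1)c1ccc(O)c(OC)c1` carries a 2-(methoxymethyl)-1-methylpropyl group on a saturated chain carbon bound to two aromatic carbons. In a functional assay on HeLa cells (Homo sapiens) for cytotoxicity, read by WST assay, with a stated time of 48 h (on this read-out higher numbers stand for weaker inhibition and lower numbers for stronger inhibition), compound 1 gives 72000 nM, the highest of the two numbers in the set. Compound 2 `COc1cc(C(c2ccc(O)c(OC)c2)[C@H](C)[C@@H](C)CO)ccc1O` reaches only a limit of the assay, > 100000 nM; the step of an at least 1.3-fold higher number from compound 1 to compound 2 (0.14 log units; that floor lies within the scatter) carries no weight. For the measured compounds named here, compound 3 `CCCCC[C@H](C(C)C)C(c1ccc(O)c(OC)c1)c1ccc(O)c(OC)c1` gives 9200 nM, and the step of a 7.8-fold lower number from compound 1 to compound 3 (0.89 log units; beyond the scatter) is the only step beyond the scatter that starts from compound 1; the step of an at least 10-fold lower number from compound 2 to compound 3 (1.03 log units; beyond the scatter) points the same way.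

Compound 4 `COc1cc(C(c2ccc(O)c(OC)c2)[C@@H](CF)C(C)C)ccc1O` differs from compound 1 by 1-(fluoromethyl)-2-methylpropyl in place of 2-(methoxymethyl)-1-methylpropyl on a saturated chain carbon bound to two aromatic carbons. The change removes the methoxymethyl of compound 1 and brings in the isopropyl branching seen in compound 3, though without the longer chain of compound 3. The step from compound 1 to compound 3 is the nearest guide, so the expected step of a 2.1-fold lower number from compound 1 to compound 4 (0.31 log units; beyond the scatter) is a modest lowering, smaller than that seen for compound 3. Compound 4 is therefore estimated at 35000 nM in this assay, within a range from 12000 nM to 100000 nM.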

Compound 4, half-maximal inhibitory concentration: 41000 nM
For compound 4 the middle estimate is 1.2-fold (0.07 log units) below the measured one; measured number inside the range.
By their numbers in this assay, from the lowest: compound 3; then compounds 4 and 1 (each within the scatter of the next). At a limit, above all of these: compound 2.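

At this place, on a saturated chain carbon bound to two aromatic carbons, the step of a 1.8-fold lower number from compound 1 to compound 4 (0.24 log units; within the scatter) shows that 1-(fluoromethyl)-2-methylpropyl and 2-(methoxymethyl)-1-methylpropyl cannot be told apart in this assay. The step of a 4.5-fold higher number from compound 3 to compound 4 (0.65 log units; beyond the scatter) shows that isopropyl branching alone, without the longer chain of 1-isopropylhexyl, does not reach the number of compound 3, whose steps to all three other compounds lie beyond the scatter. The step of an at least 2.4-fold lower number from compound 2 to compound 4 (0.38 log units; beyond the scatter) is only a floor, read against a limit: the limit of > 100000 nM in this assay, at which 1 of the 4 values shown sits.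

Still open, from the compounds shown here alone, is how a 1-isopropylbutyl or 1-isopropyloctyl group would read at this place, which would show how far the number follows chain length. Also open, going by these compounds, is whether an amine or a carboxylic acid on the chain would move the number at all.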